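The source may hold more compounds than are shown below. What is called first, only, known or untested is meant among the compounds shown, and "the series" means these compounds.

In a functional assay on the whole organism (brain) with Mus musculus as the target (on this read-out higher numbers stand for an effect only at larger amounts of compound and lower numbers for an effect already at smaller amounts), compound 2 (`FC(F)(F)c1ccc(OCCc2c[nH]cn2)cc1`) gives > 10 mg/kg, which is a limit of the assay and not a number. With propanoyl where compound 2 has trifluoromethyl, compound 1 (`CCC(=O)c1ccc(OCCc2c[nH]cn2)cc1`) gives 0.95 mg/kg. Within the data shown here, the only measured step that bears on the next change is an at least 10-fold higher number from compound 1 to compound 2 (1.02 log units; beyond the scatter), a large step beyond the scatter at the same aromatic carbon. Compound 3 (`Cc1ccc(OCCc2c[nH]cn2)cc1`) has methyl in place of trifluoromethyl on an aromatic carbon, (methyl in place of trifluoromethyl on an aromatic carbon). Among the measured compounds shown here, no measured step involves methyl, and the step of an at least 10-fold higher number from compound 1 to compound 2 (1.02 log units; beyond the scatter) concerns propanoyl, so only a small change towards lower numbers, possibly none beyond the scatter, is expected in this assay. The expected step is an at least 1.2-fold lower number from compound 2 to compound 3 (0.09 log units; that floor lies within the scatter). For compound 3 the estimated value is 8 mg/kg, with an expected range from 2 mg/kg to 30 mg/kg.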

Compound 3, dose for half-maximal effect: 2.3 mg/kg
Beside the measured number, compound 3's estimate is 3.5-fold (0.54 log units) above it; the range from low to high includes it.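

At the aromatic carbon para to a group of 8 heavy atoms, in this assay, replacing trifluoromethyl with methyl gives an at least 4.3-fold lower number from compound 2 to compound 3 (0.63 log units; beyond the scatter), so the loss seen with trifluoromethyl is not shared by every replacement of propanoyl. Methyl still does not match propanoyl, as the change between those two groups gives a 2.4-fold higher number from compound 1 to compound 3 (0.38 log units; beyond the scatter), and compound 1 keeps the lowest number of the three. For compound 2 the reading remains a limit and not a number, so its step gives only a floor: the limit of > 10 mg/kg in this assay, at which 1 of the 3 values shown sits.

The compounds shown leave open whether the carbonyl of propanoyl or its chain matters more, which an ethyl or propyl group or an acetyl group at this carbon would help to separate. On these data alone, how an amine or a carboxylic acid at this carbon would read also remains open.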